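From Phenyl to 1-Benzofuran-2-yl at the Assay Limit

The source may report more compounds than this note shows. Statements on the series, on what has been measured and on what is new or still open speak of the compounds shown alone.

Compound 1 (`CN(C)c1ncnc2c1c(-c1cc3ccccc3o1)cn2[C@@H]1O[C@H](CO)[C@@H](O)[C@H]1O`): > 20000 nM (a limit)
Compound 2 (`O=c1[nH]cnc2c1c(-c1ccccc1)cn2[C@@H]1O[C@H](CO)[C@@H](O)[C@H]1O`): > 20000 nM (a limit)

Both entries come from a functional assay on HL-60 cells (Homo sapiens) for antiproliferative activity, read by XTT assay, with a stated time of 72 h (on this read-out lower numbers stand for stronger inhibition and higher numbers for weaker inhibition), and neither is an exact number, since each is a limit of the assay. Compound 2 stands at the limit of > 20000 nM in this assay, at which 2 of the 2 values shown sit, on the numbers shown so far.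

The compound still to be tested is compound 3 (`O=c1[nH]cnc2c1c(-c1cc3ccccc3o1)cn2[C@@H]1O[C@H](CO)[C@@H](O)[C@H]1O`). It keeps the core of compound 2 but carries 1-benzofuran-2-yl in place of phenyl on an aromatic carbon (counted change: 1-benzofuran-2-yl in place of phenyl on an aromatic carbon).

Among the measured compounds shown here, no two measured compounds differ in only one place, so no measured step shows how large this change might be. The nearest clue is that compound 1 also carries 1-benzofuran-2-yl, and compound 1 gives > 20000 nM as a limit of the assay. On that basis, no step beyond the usual scatter is expected in this assay, and another limit is the likeliest report. The expected move is a number no higher from compound 2 to compound 3 (the limit leaves the size open) and no larger. For compound 3 the estimated value is 20000 nM with an expected range from 8000 nM to 40000 nM in this read-out.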

Compound 3, half-maximal inhibitory concentration: > 20000 nM
Compound 3: only a limit was reported (the forecaster's own chance of this, stated with the estimate: 85%); the middle value sits exactly at the limit.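

Compound 2 and compound 3 both end at a limit of this assay rather than at an exact number, so no step can be read between them: the limit of > 20000 nM in this assay, at which 3 of the 3 values shown sit.

The compounds shown leave open whether 1-benzofuran-2-yl in place of phenyl on an aromatic carbon shifts the activity at all, and which change would give a measurable number.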